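This account rests on a few compounds, and the source may have more. Where it says the series, first, only, none or still open, it means among the compounds named here.

Measured so far:
- Compound 1, `COc1ccc(/C=C/C2CC(=O)C=CO2)cc1OC`: 74.3 uM in a functional assay on OVCAR-3 cells (Homo sapiens) for inhibition, read by sulforhodamine B assay, with a stated time of 48 h; a lower number here means a stronger inhibitor of growth, a higher number a weaker inhibitor of growth
- Compound 2, `COc1ccc(C2CC(=O)C=CO2)cc1`: 249 uM in this assay

Compound 2 stands with the highest of the two numbers in this assay; compound 1, its nearest neighbour, sits a step below it that lies beyond the usual scatter. Compound 3, `COc1ccc(C2CC(=O)C(Br)=CO2)cc1`, has not yet been measured. It differs from compound 2 in one place: bromo in place of hydrogen on a double-bonded ring carbon. Going by the values given here, no measured pair shows what such a change does here, so the step from compound 2 to compound 3 is expected to be small, toward a lower number, and within the scatter. Compound 3 is expected to give 160 uM, in a range from 45 uM to 500 uM.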

Compound 3, concentration for growth inhibition (reported as GI): 114 uM
Compound 3: middle estimate off by 1.4-fold (0.15 log units), on the high side; the range from low to high includes it.
By their numbers in this assay, from the lowest: compounds 1 and 3 (each within the scatter of the next); then compound 2.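

Going by these compounds alone, this is the first look at the double-bonded ring carbon two ring bonds from the ring oxygen: in this assay, bromo in place of hydrogen brings a 2.2-fold lower number from compound 2 to compound 3 (0.34 log units; beyond the scatter). A change of a single atom at this carbon is therefore enough to move the number, and here the compound becomes a stronger inhibitor of growth. Nothing shown explains this step.

On these data alone, whether chloro, a methyl group or an amine at this carbon would move the number the same way remains open. So does whether bromo would give a similar step on the core of compound 1.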